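The source may report more compounds than this note shows. Statements on the series, on what has been measured and on what is new or still open speak of the compounds shown alone.

Measured in an ADME assay on Vero cells (Chlorocebus sabaeus) for cytotoxicity, read by resazurin assay, with a stated time of 72 h; on this read-out higher numbers stand for weaker inhibition and lower numbers for stronger inhibition:
Compound 1 `COc1ccc(C(=O)CCN2CCN(c3ccc(F)cc3)CC2)cc1`: 55000 nM
Compound 2 `COc1ccc(C(=O)CCN2CCN(c3ccc(Cl)cc3)CC2)cc1`: 300000 nM
Compound 3 `O=C(CCN1CCN(c2ccc(Cl)cc2)CC1)c1ccc(F)c(Br)c1`: 206000 nM

Compound 2, at 300000 nM, sits level with compound 3 and clear of compound 1. Compound 4 `O=C(CCN1CCN(c2ccc(Cl)cc2)CC1)c1ccc(OC(F)(F)F)cc1` departs from compound 2 by one change (trifluoromethyl in place of methyl on an oxygen on an aromatic ring), with trifluoromethyl in place of methyl on an oxygen on an aromatic ring. The nearest evidence is a 1.5-fold lower number from compound 2 to compound 3 (0.16 log units; within the scatter), which alters the same aromatic group and stays within the scatter. The other step, a 5.5-fold higher number from compound 1 to compound 2 (0.74 log units; beyond the scatter), is larger but lies elsewhere in the molecule, so it bears only weakly. No change beyond the scatter is therefore expected, and the estimated step is a 1.5-fold lower number from compound 2 to compound 4 (0.18 log units; within the scatter). For compound 4 the expected value is 200000 nM, within an estimated range of 70000 nM to 450000 nM.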

Compound 4, half-maximal inhibitory concentration: 95600 nM
Compound 4: the middle estimate sits 2.1-fold (0.32 log units) above what was measured; measured number inside the range.
By their numbers in this assay, from the lowest: compounds 1 and 4 (each within the scatter of the next); then compounds 3 and 2 (each within the scatter of the next).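

In this assay, the change from methoxy to trifluoromethoxy gives a 3.1-fold lower number from compound 2 to compound 4 (0.50 log units; beyond the scatter), so a change on this oxygen alone moves the number beyond the scatter, which the earlier step replacing the whole 4-methoxyphenyl group did not do. Nothing available explains this shift.

On these data alone, it remains open whether other groups on this oxygen, such as ethyl or difluoromethyl, would shift the number in the same way. As far as these compounds go, it is also open whether the change would carry over to compound 1, which bears fluoro in place of chloro.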